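This account rests on a few compounds, and the source may have more. Where it says the series, first, only, none or still open, it means among the compounds named here.

Measured so far in an assay on HEK293 cells for inhibition of Voltage-dependent T-type calcium channel subunit alpha-1G (Homo sapiens), read by fluorescence, tested at 10 uM; on this read-out lower numbers stand for less inhibition and higher numbers for more inhibition at the one concentration tested (going by the name of the read-out):
Compound 1 `CCCc1nc(-c2ccccc2)c(CNCCCN2CCN(c3cccc(C)c3)CC2)o1` gives 47.8%.
Compound 2 `CCCc1nc(-c2ccccc2)c(CNCCCN2CCN(c3ccc(C(F)(F)F)cc3)CC2)o1` gives 51.6%.
Compound 3 `CCCc1nc(-c2ccccc2)c(CNCCCN2CCN(c3ccc(Cl)cc3)CC2)o1` gives 63.3%.

Compound 3 stands highest of the three numbers; the nearest is compound 2, separated by a number 11.7 percentage points higher from compound 2 to compound 3 (beyond the scatter), and the furthest is compound 1, separated by a number 15.5 percentage points higher from compound 1 to compound 3 (beyond the scatter), both steps beyond the scatter. The two steps leading to compound 3 each swap the group on the aromatic ring carried by the amine nitrogen in the ring, and both land lower than the chloro variant.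

Compound 4 `CCCc1nc(-c2ccccc2)c(CNCCCN2CCN(c3ccc(OC)cc3)CC2)o1` differs from compound 3 by methoxy in place of chloro on an aromatic carbon. Going by the values given here, no measured pair exchanges chloro for methoxy, so the bearing steps are only indirect: the chloro compound sits above both the trifluoromethyl and the 3-methylphenyl variants, by a number 11.7 percentage points higher from compound 2 to compound 3 (beyond the scatter) and a number 15.5 percentage points higher from compound 1 to compound 3 (beyond the scatter). On that basis a modest move downward in this assay is expected for compound 4, on the order of a number 11.3 percentage points lower from compound 3 to compound 4 (beyond the scatter). Compound 4 is estimated at 52%, within 38% to 66%.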

Compound 4, a percentage reported as inhibition, at one concentration (the size of the read-out at that concentration, not a potency): 42.1%
The estimate for compound 4 lay 9.9 percentage points above the measured number, within the range that was stated.
By their numbers in this assay, from the lowest: compounds 4, 1 and 2 (each within the scatter of the next); then compound 3.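

In this assay, on an aromatic carbon para to a large group, the change from chloro to methoxy gives a number 21.2 percentage points lower from compound 3 to compound 4 (beyond the scatter) and removes the lead held by compound 3. Methoxy offers no gain over the other substituted phenyl groups, with a number 9.5 percentage points lower from compound 2 to compound 4 (within the scatter) and a number 5.7 percentage points lower from compound 1 to compound 4 (within the scatter) both falling within the scatter, so compound 3 is now the only compound with steps beyond the scatter to all the others. No measurement shown here accounts for the drop on moving from chloro to methoxy.

On these data alone, it remains open whether the higher reading is particular to chloro or is shared by 4-fluorophenyl or 4-bromophenyl. Also open is whether the same order among these groups would hold with a longer chain elsewhere on the shared core.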